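Replacing the 1-methylpiperidin-4-yl group of compound 2

The source may hold more compounds than are shown below. What is called first, only, known or untested is meant among the compounds shown, and "the series" means these compounds.

In a physicochemical assay for solubility, in phosphate buffer, with a stated time of 24 h, at pH 7.4, tested at 100 uM (a lower number here means a less soluble compound, a higher number a more soluble compound), compound 1 `O=C(NCc1ccc(S(=O)(=O)C2CCN(C3COC3)CC2)cc1)N1Cc2ccncc2C1` gives 121000 nM and compound 2 `CN1CCC(S(=O)(=O)c2ccc(CNC(=O)N3Cc4ccncc4C3)cc2)CC1` gives 240000 nM. Among the compounds with values here, compound 2 therefore stands level with compound 1, as the only measured step, a 2.0-fold higher number from compound 1 to compound 2 (0.30 log units; within the scatter), lies within the scatter. That step put methyl in place of oxetan-3-yl on an amine nitrogen in a ring.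

Compound 3 `O=C(NCc1ccc(S(=O)(=O)N2CC3(CCOCC3)C2)cc1)N1Cc2ccncc2C1` has not yet been measured. It departs from compound 2 at one place: a group of 9 heavy atoms (7 carbon, 1 nitrogen, 1 oxygen; one four-membered non-aromatic ring with 1 hetero atom, one six-membered non-aromatic ring with 1 hetero atom) in place of a group of 7 heavy atoms (6 carbon, 1 nitrogen; one six-membered non-aromatic ring with 1 hetero atom), on a sulfonyl sulfur. This change removes the whole 1-methylpiperidin-4-yl group, not just the substituent on its nitrogen, so the step from compound 1 is only a weak guide. Within the data shown here, no measured pair shows a change of this kind. The data show only that one substitution on the amine nitrogen, a 2.0-fold higher number from compound 1 to compound 2 (0.30 log units; within the scatter), stayed within the scatter.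

With both measured compounds sitting high, a moderate drop in this assay is expected, though this is a judgement and the range is kept wide. The expected change is a 4.0-fold lower number from compound 2 to compound 3 (0.60 log units; beyond the scatter). For compound 3 the estimated value is 60000 nM, within an expected range of 12000 nM to 200000 nM.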

Compound 3, solubility: 272000 nM
The estimate for compound 3 lay 4.5-fold (0.66 log units) below the measured number; measured number outside the range, above it.
By their numbers in this assay, from the lowest: compounds 1, 2 and 3 (each within the scatter of the next, the first and the last beyond it).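

In this assay the change reaches further than the earlier step did: the whole group on the sulfonyl sulfur was exchanged, not just the substituent on an amine nitrogen in a ring. Putting the group of 9 heavy atoms, with its four-membered and six-membered rings, in place of 1-methylpiperidin-4-yl gives a 1.1-fold higher number from compound 2 to compound 3 (0.05 log units; within the scatter) and so leaves compound 3 level with compound 2, while the same entering group, set against the group carried by compound 1, gives a 2.2-fold higher number from compound 1 to compound 3 (0.35 log units; beyond the scatter) as a modest step, the only one among these three compounds beyond the scatter. Nothing available accounts for either step.

The compounds shown leave open whether this level reading would hold for a quite different group on the sulfonyl sulfur, such as a morpholine, an open-chain amine or a group bearing a carboxylic acid. Within the data shown here, they also leave open what each ring of the entering group contributes, since no compound here carries the four-membered ring without the six-membered ring attached to it.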